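Amino Added to the Methoxyphenyl Arm of Compound 1

The source may hold more compounds than are shown below. What is called first, only, known or untested is meant among the compounds shown, and "the series" means these compounds.

Measured so far, in a functional assay on PC-3 cells (Homo sapiens) for antiproliferative activity, read by MTT assay, with a stated time of 48 h; a higher number here means a weaker inhibitor of growth, a lower number a stronger inhibitor of growth:
compound 1, `COc1ccc(/C=C2\Cc3c(cc(OC)c(OC)c3OC)C2=O)cc1`: compound 1 gives 750 nM
compound 2, `COc1cc(/C=C2\Cc3c(cc(OC)c(OC)c3OC)C2=O)cc(OC)c1OC`: compound 2 gives 4990 nM
compound 3, `COc1cc2c(c(OC)c1OC)C/C(=C\c1cc(OC)c(OC)c(OC)c1OC)C2=O`: compound 3 gives > 10000 nM, which is a limit of the assay and not a number

Compound 1 carries the lowest of the two numbers shown, with compound 2 the nearest at a gap that lies beyond the usual scatter. Compound 3 sits at the limit of > 10000 nM in this assay, at which 1 of the 3 values shown sits. Among the measured compounds shown here, the only step between two measured compounds that differ in one place is an at least 2.0-fold higher number from compound 2 to compound 3 (0.30 log units; that floor lies within the scatter), where a methoxy enters on an aromatic carbon.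

Compound 4, `COc1ccc(/C=C2\Cc3c(cc(OC)c(OC)c3OC)C2=O)cc1N`, differs from compound 1 by amino in place of hydrogen on an aromatic carbon. For the measured compounds named here, no measured step adds an amino, so the step from compound 2 to compound 3 bears on this only loosely, as the one case where a single group entered the same kind of ring and the number rose. Taking that as a weak hint, a small change in this assay, possibly toward a higher number, but within or near the scatter, is expected, and compound 4 is estimated at 900 nM, between 200 nM and 4000 nM. The expected step is a 1.2-fold higher number from compound 1 to compound 4 (0.08 log units; within the scatter).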

Compound 4, concentration for 50% growth inhibition: 456 nM
Compound 4: middle estimate off by 2.0-fold (0.30 log units), on the high side, and the stated range covers the measured number.
By their numbers in this assay, from the lowest: compounds 4 and 1 (each within the scatter of the next); then compound 2. At a limit, above all of these: compound 3.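

In this assay, putting an amino in place of hydrogen gives a 1.6-fold lower number from compound 1 to compound 4 (0.22 log units; within the scatter), so compound 4 and compound 1 cannot be told apart. The earlier compounds shown here carry only methoxy groups on this arm, whereas compound 4 shows that this place, ortho to a methoxy group and meta to a large group, can hold an amino, with its hydrogen-bond donor, while the number stays within the scatter of that of compound 1. Nothing in the data shown accounts for this result, and no measured property of the amino group bears on it.

Going by these compounds, it remains open whether a hydroxyl, an acetamide or a dimethylamino group at this same place would also stay within the scatter of compound 1, or would shift the number clearly in either direction. On these data alone, it is also open whether an amino in place of hydrogen would behave the same way on the more heavily methoxylated arm of compound 2, since a single step on one arm says little about another.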